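Swapping the amine end on a shared core

A few compounds are considered here, and "the series" means these few. Any claim that something is new, unique, unknown or untested is made for them only; others in the source may bear on it.

Measured so far in a functional assay on cells (Homo sapiens) for antiproliferative activity, read by MTT assay, with a stated time of 48 h (a lower number here means a stronger inhibitor, a higher number a weaker inhibitor), as follows
Compound 1 `CCN(CC)CCCCn1c(N)c(-c2nc3ccccc3o2)c2nc(C#N)c(C#N)nc21` gives 2710 nM
Compound 2 `CN(C)CCn1c(N)c(-c2nc3ccccc3n2C)c2nc(C#N)c(C#N)nc21` gives > 50000 nM as a limit of the assay
Compound 3 `CN(C)CCCCn1c(N)c(-c2nc3ccccc3n2C)c2nc(C#N)c(C#N)nc21` gives 1790 nM

Compound 3 (1790 nM) lies within the scatter of compound 1 (2710 nM), so the two cannot be ranked. Compound 4 `CCN(CC)CCCCn1c(N)c(-c2nc3ccccc3n2C)c2nc(C#N)c(C#N)nc21` keeps everything in compound 3 except the amine end, and the change is diethylamino in place of dimethylamino on a saturated chain carbon, four bonds along the chain from an aromatic nitrogen in all. It is diethylamino in place of dimethylamino on a saturated chain carbon, four bonds along the chain from an aromatic nitrogen.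

Within the data shown here, the one measured step, an at least 27-fold lower number from compound 2 to compound 3 (1.44 log units; beyond the scatter), alters the chain and leaves the dimethylamino group itself in place. It therefore bears on the new change only indirectly, and its large size is no guide here. The closer evidence is compound 1 (2710 nM), which already carries diethylamino on the same chain but differs elsewhere on the core. Its value gives no reason to expect a shift beyond the scatter in this assay when the amine end changes. The estimated change is a 1.2-fold higher number from compound 3 to compound 4 (0.09 log units; within the scatter), and no clear direction is expected. For compound 4 the estimated value is 2200 nM (900 nM to 5500 nM).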

Compound 4, half-maximal inhibitory concentration: 2890 nM
Compound 4: middle estimate off by 1.3-fold (0.12 log units), on the low side; the range from low to high includes it.
By their numbers in this assay, from the lowest: compounds 3, 1 and 4 (each within the scatter of the next). At a limit, above all of these: compound 2.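

Among these compounds, with the chain and the rest of the core held fixed, this assay gives a 1.6-fold higher number from compound 3 to compound 4 (0.21 log units; within the scatter), which is the first reading of the amine end on its own, and at this place, on a saturated chain carbon, four bonds along the chain from an aromatic nitrogen, diethylamino and dimethylamino cannot be told apart. With diethylamino on the same chain, the change at the other end of the molecule, 1-methyl-1H-benzimidazol-2-yl in place of 1,3-benzoxazol-2-yl on an aromatic carbon, also stays within the scatter, as a 1.1-fold higher number from compound 1 to compound 4 (0.03 log units; within the scatter) shows, so neither single change among compounds 1, 3 and 4 separates them. The remaining step, an at least 17-fold lower number from compound 2 to compound 4 (1.23 log units; beyond the scatter), alters the chain and the amine end together and gives only a bound, set by the limit reached by compound 2: the limit of > 50000 nM in this assay, at which 1 of the 4 values shown sits.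

The compounds shown leave open whether 2-(diethylamino)ethyl on the same core would sit at that limit as well, which would tie the loss to chain length rather than to the amine end. They also leave open whether a ring amine such as piperidine or morpholine, or a chain longer than four carbons, would move the number beyond the scatter.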